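This account rests on a few compounds, and the source may have more. Where it says the series, first, only, none or still open, it means among the compounds named here.

Measured in a functional assay on HeLa cells (Homo sapiens) for antiproliferative activity, read by MTT assay, with a stated time of 48 h; on this read-out higher numbers stand for weaker inhibition and lower numbers for stronger inhibition:

compound 1, `Cc1ccc2[nH]c(-c3cn(-c4ccccc4)nc3-c3ccccc3)nc2c1`: 6560 nM
compound 2, `O=C(OCc1ccccc1)c1ccc2[nH]c(-c3cn(-c4ccccc4)nc3-c3ccccc3)nc2c1`: 21300 nM
compound 3, `Cc1ccc2[nH]c(-c3cn(-c4ccccc4)nc3-c3ccc(Cl)cc3)nc2c1`: 5360 nM

Compound 4, `O=C(OCc1ccccc1)c1ccc2[nH]c(-c3cn(-c4ccccc4)nc3-c3ccc(Cl)cc3)nc2c1`, is not yet measured. Its core differs from that of compound 1 by chloro in place of hydrogen on an aromatic carbon, a change that gave a 1.2-fold lower number from compound 1 to compound 3 (0.09 log units; within the scatter). Against that core compound 4 carries the change (benzyloxycarbonyl in place of methyl on an aromatic carbon). The same change has been measured once already, as benzyloxycarbonyl in place of methyl on an aromatic carbon, where it gave a 3.2-fold higher number from compound 1 to compound 2 (0.51 log units; beyond the scatter); the place of the change is described in the same words for both pairs, so it counts as the same change. On that single precedent, compound 4 is expected to show a step of a 3.2-fold higher number from compound 3 to compound 4 (0.50 log units; beyond the scatter), resting on a 3.2-fold higher number from compound 1 to compound 2 (0.51 log units; beyond the scatter). Compound 4 is accordingly estimated at 17000 nM, with a range from 8000 nM to 36000 nM.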

Compound 4, half-maximal inhibitory concentration: 8130 nM
For compound 4 the middle estimate is 2.1-fold (0.32 log units) above the measured one; low and high end bracket the measured number.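

In this assay, benzyloxycarbonyl in place of methyl gives a 1.5-fold higher number from compound 3 to compound 4 (0.18 log units; within the scatter), and its two readings do not differ beyond the scatter: the same change on two cores in this assay, a 3.2-fold higher number (0.51 log units; beyond the scatter) from compound 1 to compound 2 and a 1.5-fold higher number (0.18 log units; within the scatter) from compound 3 to compound 4, 2.1-fold (0.33 log units) apart, within the scatter of two such steps. Chloro in place of hydrogen gives a 2.6-fold lower number from compound 2 to compound 4 (0.42 log units; beyond the scatter), and its two readings also agree within the scatter: the same change on two cores in this assay, a 1.2-fold lower number (0.09 log units; within the scatter) from compound 1 to compound 3 and a 2.6-fold lower number (0.42 log units; beyond the scatter) from compound 2 to compound 4, 2.1-fold (0.33 log units) apart, within the scatter of two such steps. Each change therefore carries between these cores without a resolved dependence on the core, but two pairs from four compounds can neither exclude a modest core effect nor show that the agreement extends to other cores.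

From the compounds shown here alone, it remains open whether a carboxylic acid or an amide in place of benzyloxycarbonyl, or fluoro or methoxy in place of chloro, would follow the same steps. Going by these compounds, whether these steps hold on other cell lines is also open.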